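The source may hold more compounds than are shown below. What is called first, only, known or untested is meant among the compounds shown, and "the series" means these compounds.

Compound 1 `Cc1ccc([S+]([O-])N2CCC[C@H]2COCCCCCC/C=C/c2ccc(-c3ccccc3)cc2)cc1` gives in a functional assay on PANC-1 cells (Homo sapiens) for inhibition, read by XTT assay, with a stated time of 72 h (on this read-out lower numbers stand for stronger inhibition and higher numbers for weaker inhibition), only a limit of the assay, >= 100000 nM.
Compound 2 `Cc1ccc([S+]([O-])N2CCC[C@H]2COCCCCCCCCC/C=C/c2ccc(-c3ccccc3)cc2)cc1` gives in this assay likewise only a limit, > 100000 nM.
Compound 3 `O=CN1CCC[C@H]1COCCCCCC/C=C/c1ccc(-c2ccccc2)cc1` gives in this assay a number, 50000 nM.

Compound 1 and compound 2 are two cores of the series; how they differ is not broken down here. Compound 3 arises from compound 1 by a single change: a group of 2 heavy atoms (1 carbon, 1 oxygen; no ring) in place of a group of 9 heavy atoms (7 carbon, 1 oxygen, 1 sulfur; one six-membered aromatic ring of carbon only), on an amine nitrogen in a ring. In this assay this gave an at least 2.0-fold lower number from compound 1 to compound 3 (0.30 log units; that floor lies within the scatter). Because the limit of >= 100000 nM in this assay, at which 1 of the 3 values shown sits, is where compound 1 sits, this step can only be read as a floor, not as a full size.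

Compound 4 `O=CN1CCC[C@H]1COCCCCCCCCC/C=C/c1ccc(-c2ccccc2)cc1` has not yet been measured. It arises from compound 2 by the same change: a group of 2 heavy atoms (1 carbon, 1 oxygen; no ring) in place of a group of 9 heavy atoms (7 carbon, 1 oxygen, 1 sulfur; one six-membered aromatic ring of carbon only), on an amine nitrogen in a ring. The place is described in the same words in both cases, so it is the same change, made on the other core. Compound 2 sits at the limit of > 100000 nM in this assay, at which 1 of the 3 values shown sits, so whatever compound 4 shows, the step from compound 2 can again only be read as a floor.

For compound 4 in this assay a value near 60000 nM is expected, somewhere from 20000 nM to 200000 nM. That would mean an estimated step of an at least 1.6-fold lower number from compound 2 to compound 4 (0.22 log units; that floor lies within the scatter). This expectation rests on compound 3, which after the same change gives 50000 nM. It also rests on compound 4 carrying the longer chain of compound 2.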

Compound 4, half-maximal inhibitory concentration: 56700 nM
Compound 4: the middle estimate sits 1.1-fold (0.02 log units) above what was measured; low and high end bracket the measured number.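

On the core of compound 2, putting formyl in place of the larger group on the amine nitrogen of the five-membered ring gave in this assay an at least 1.7-fold lower number from compound 2 to compound 4 (0.24 log units; that floor lies within the scatter). In both pairs, the compound with formyl gives a measured number, while its parent gives only a limit, so the change carries over to the second core in this plain sense, and the two steps can be set side by side only as floors: the same change on two cores in this assay, an at least 2.0-fold lower number (0.30 log units; that floor lies within the scatter) from compound 1 to compound 3 and an at least 1.7-fold lower number (0.24 log units; that floor lies within the scatter) from compound 2 to compound 4; the limit leaves it open whether they differ. On these data alone, the real size of the new step remains unknown, and so does any match in size between the two steps, since compound 2 gives only a limit of the assay, > 100000 nM.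

The compounds shown leave open whether the formyl group itself matters or whether removing the larger group is enough, which a free ring amine or an acetyl or methyl group on the same nitrogen could help to separate. They also leave open what a much shorter chain, or a carboxylic acid or an amine at the end of the chain, would do on the formyl compounds in this assay.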